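The source may hold more compounds than are shown below. What is called first, only, known or untested is meant among the compounds shown, and "the series" means these compounds.

Compound 1 `OC[C@H]1OC(n2cnc3c(SCc4ccccc4)nccc32)[C@H](O)[C@@H]1O` gives 30% in a functional assay (Homo sapiens) for inhibition of Nucleic Acid, tested at 100 uM; a higher number here means more inhibition at the concentration tested (going by the name of the read-out), a lower number less inhibition.
Compound 2 `[O-][n+]1ccc2[nH]cnc2c1` gives 3% in this assay.

Of these two numbers, compound 1 stands highest, and its gap to compound 2 lies beyond the usual scatter. Compound 3 `OCCNc1nccc2c1ncn2C1O[C@H](CO)[C@@H](O)[C@H]1O` differs from compound 1 in one place: (2-hydroxyethyl)amino in place of benzylsulfanyl on an aromatic carbon. Within the data shown here, no measured pair here shows what this exchange does, so the expected step from compound 1 to compound 3 in this assay is a modest loss of inhibition that may not exceed the scatter, a number 10 percentage points lower from compound 1 to compound 3 (within the scatter). Compound 3 is therefore estimated to give 20%, expected to lie between 5% and 40%.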

Compound 3, a percentage reported as inhibition, at one concentration (the size of the read-out at that concentration, not a potency): 0%
Estimate against measurement, compound 3: 20 percentage points above, outside the stated range (below it).
By their numbers in this assay, from the lowest: compounds 3 and 2 (each within the scatter of the next); then compound 1.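

On an aromatic carbon next to the ring nitrogen, the group matters: putting (2-hydroxyethyl)amino in place of benzylsulfanyl brings a number 30 percentage points lower from compound 1 to compound 3 (beyond the scatter) in this assay on the same core. Among these compounds, this is the first measured sign that inhibition depends on what sits at this position, since compound 2 differs from compound 1 in more than one place. No available evidence gives a reason for the drop. Still open, as far as these compounds go, is whether the aromatic ring or the sulfur of benzylsulfanyl matters more. Benzylamino or methylsulfanyl at this position would separate the two.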